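Swapping a thiourea for a propanamide in a melatonin series

The compounds below may be only part of what the source reports. "The series", "measured", "known", "first", "only" and "open" are said of these compounds alone.

Three compounds in this set carry the same saturated bicyclic core with a short chain ending in a nitrogen, and they differ in what sits on that nitrogen and on the core. Compound 1 `CCNC(=O)NCC1CCc2c(OC)cccc2N1C` gives 92% in a functional assay on CHO cells with melatonin receptor type 1A (Homo sapiens) as the target, read by GTPgammaS binding, with a stated time of 1 h; a higher number here means a larger maximal response, a lower number a smaller maximal response. Compound 2 `CCNC(=O)NCC1CCc2c(cccc2OC)N1` is recorded in this assay as "not determined" (no result reported), so it contributes no number. Compound 3 `CCNC(=S)NCC1CCc2ccccc2N1`, which carries a thiourea, gives 35% in this assay, the lowest of the two numbers available; compound 1 stands well above it, by a margin beyond the usual scatter.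

Compound 4 `CCC(=O)NCC1CCc2ccccc2N1` has not been measured yet. Its difference from compound 3 is a group of 4 heavy atoms (3 carbon, 1 oxygen; no ring) in place of a group of 5 heavy atoms (3 carbon, 1 nitrogen, 1 sulfur; no ring), on an amine nitrogen. Among the measured compounds shown here, since no measured pair in the set shows this particular exchange, the size of its effect must be guessed from the one comparison at hand: compound 3, the only compound with a thiourea, gives the smallest response, while compound 1, with a urea, reaches a near-full response. The expected step from compound 3 to compound 4 is therefore estimated as a number 40 percentage points higher from compound 3 to compound 4 (beyond the scatter), an increase in maximal response that should clear the scatter. Compound 4 is expected to give 75% in this assay, with a likely range from 45% to 100%.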

Compound 4, largest response reached (Emax), in percent of the reference or control that the assay uses: 37%
Compound 4: the middle estimate sits 38 percentage points above what was measured, and the stated range ends above it.
By their numbers in this assay, from the lowest: compounds 3 and 4 (each within the scatter of the next); then compound 1.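

On the amine nitrogen of this shared core, exchanging the thiourea for propanoyl in this assay gives a number 2 percentage points higher from compound 3 to compound 4 (within the scatter), so the two groups cannot be told apart by their maximal response. Among the compounds shown here, this is the first direct look at this exchange, and it shows that the response stays within the usual scatter even though sulfur and a nitrogen leave, oxygen enters, and the count of hydrogen-bond donors goes from 1 in the leaving group to 0 in propanoyl. Nothing in the data explains why the response holds steady across this exchange.

Compound 1, at 92%, differs from compound 3 and from compound 4 in more than one place, so the compounds shown cannot assign its larger response to any single group. Going by these compounds, it also remains open whether a shorter acetyl group, a longer butanoyl chain or a carboxylic acid on the same amine nitrogen would leave the response in this assay unchanged or move it beyond the scatter.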